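Swapping a branched chain for a phenyl ring

The source may hold more compounds than are shown below. What is called first, only, known or untested is meant among the compounds shown, and "the series" means these compounds.

Measured so far:
compound 1, `C#CC(=O)N1C(c2ccc(OC)cc2)SC[C@@H]1C(=O)OCC`, 700 nM
compound 2, `C#CC(=O)N1C(C(C)CCC)SC[C@@H]1C(=O)OCC`, 500 nM

Both were tested in a functional assay on MV cells (Homo sapiens) for inhibition, read by sulforhodamine B assay; a lower number here means a stronger inhibitor, a higher number a weaker inhibitor. Compound 2 gives the lower of the two numbers, but compound 1 sits within the usual scatter of it, so the two cannot be told apart. Compound 3, `C#CC(=O)N1C(c2ccccc2)SC[C@@H]1C(=O)OCC`, is not yet measured. It differs from compound 2 in one place: phenyl in place of 1-methylbutyl on a saturated ring carbon. Compound 1 carries a closely related aromatic group and does not stand apart from compound 2, so the step of a 1.2-fold higher number from compound 2 to compound 3 (0.08 log units; within the scatter) is expected to stay within the scatter. Compound 3 is estimated at 600 nM, with a range of 250 nM to 1500 nM.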

Compound 3, half-maximal inhibitory concentration: 400 nM
The estimate for compound 3 lay 1.5-fold (0.18 log units) above the measured number; the measured number falls inside the stated range.
By their numbers in this assay, from the lowest: compounds 3, 2 and 1 (each within the scatter of the next).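

Phenyl in place of 1-methylbutyl on this saturated ring carbon gives a 1.3-fold lower number from compound 2 to compound 3 (0.10 log units; within the scatter) in this assay, so a plain aromatic ring and a branched chain cannot be told apart at this position. Hydrogen in place of methoxy on the aromatic carbon gives a 1.8-fold lower number from compound 1 to compound 3 (0.24 log units; within the scatter) and likewise leaves the numbers indistinguishable. No measurement offered here explains these results.

Still open, going by these compounds, is whether an amine or a carboxylic acid on the phenyl ring, or a longer chain at this position, would move the number beyond the scatter.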